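This account rests on a few compounds, and the source may have more. Where it says the series, first, only, none or still open, it means among the compounds named here.

Working notes on a small series built on one shared core. Compound 1 is `Cn1c(=O)[nH]c2c(cnn2-c2ccccc2[N+](=O)[O-])c1=N` and compound 2 is `Cn1c(=O)[nH]c2c(cnn2-c2cc(Cl)cc(Cl)c2)c1=N`. In an assay on membranes from brain for binding affinity to adenosine receptor A1 (Rattus norvegicus), read by radioligand binding, tested at 20 uM (a higher number here means more inhibition at the concentration tested (going by the name of the read-out), a lower number less inhibition), compound 1 gives 5%, while compound 2 gives 29%. Among the measured compounds shown here, compound 1 therefore stands at the lower of the two numbers measured so far, and its gap to compound 2 lies beyond the usual scatter of this assay, so compound 2 reads genuinely higher. For the measured compounds named here, no pair of measured compounds differs in only one place, so no measured single step is available to calibrate the change considered next.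

Compound 3 is `Cn1c(=O)[nH]c2c(cnn2-c2ccccc2N)c1=N`, not yet measured, and differs from compound 1 by amino in place of nitro on an aromatic carbon. Going by the values given here, with only two measured values and no directly comparable step in hand, the change from compound 1 to compound 3 is expected to be small, most likely within the scatter, with if anything a slight upward lean, so that a number 7 percentage points higher from compound 1 to compound 3 (within the scatter) is the estimated step in this assay. For compound 3 the expected inhibition in this assay is 12%, with a plausible range from 0% to 35%, and the lower end of that range is bounded by the floor of the read-out.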

Compound 3, a percentage reported as inhibition, at one concentration (the size of the read-out at that concentration, not a potency): 0%
For compound 3 the middle estimate is 12 percentage points above the measured one; measured number inside the range.
By their numbers in this assay, from the lowest: compounds 3 and 1 (each within the scatter of the next); then compound 2.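

In this assay the series now has its first measured single step, a number 5 percentage points lower from compound 1 to compound 3 (within the scatter) for amino in place of nitro on an aromatic carbon, ortho to a large group. At this position the exchange therefore gives no reading that separates the two groups, and compound 3 and compound 1 both sit close to the floor of the read-out, so this step shows no gain from amino here and leaves little room to see a further fall. Nothing measured in the series speaks to why the two groups read alike.

On these data alone, whether a methoxy group, a chlorine or a carboxylic acid at this same place would read any differently stays open, as does whether amino in place of nitro would behave the same way elsewhere on that aromatic ring. Compound 2 at 29% differs from compound 1 in more than one place, so the compounds shown do not tell which part of its substitution goes with that number.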